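Fluoro on the phenyl of compound 1

The source may hold more compounds than are shown below. What is called first, only, known or untested is meant among the compounds shown, and "the series" means these compounds.

For the measured compounds named here, compound 1, `COc1cc(-c2cccc3nc(-c4ccccc4)oc23)cc(OC)c1OC`, is the only member of the series with a measured number in a functional assay on NCI-H460 cells (Homo sapiens) for antiproliferative activity, read by MTT assay, with a stated time of 48 h; on this read-out lower numbers stand for stronger inhibition and higher numbers for weaker inhibition: there compound 1 gives 6800 nM. Compound 2, `COc1cccc(-c2nc3cccc(-c4cc(OC)c(OC)c(OC)c4)c3o2)c1`, returns only a limit of the assay in this assay, > 25000 nM. Compound 3, `COc1ccc(-c2nc3cccc(-c4cc(OC)c(OC)c(OC)c4)c3o2)cc1OC`, likewise returns a limit in this assay, > 25000 nM; see (the limit of > 25000 nM in this assay, at which 2 of the 3 values shown sit).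

Compound 4, `COc1cc(-c2cccc3nc(-c4ccc(F)cc4)oc23)cc(OC)c1OC`, is not yet measured. It differs from compound 1 by fluoro in place of hydrogen on an aromatic carbon.

The two readable steps both alter the same phenyl ring. Methoxy in place of hydrogen gives an at least 3.6-fold higher number from compound 1 to compound 2 (0.56 log units; beyond the scatter), and 3,4-dimethoxyphenyl in place of phenyl gives an at least 3.6-fold higher number from compound 1 to compound 3 (0.56 log units; beyond the scatter). Both weaken the activity. Fluoro is a single heavy atom without hydrogen-bond donors or acceptors, so the change in compound 4 is smaller than either measured one; a weakening step is expected, of a size that may or may not exceed the scatter.

For compound 4 the expected step is a 1.4-fold higher number from compound 1 to compound 4 (0.15 log units; within the scatter). The estimate for compound 4 in this assay is 9500 nM, between 3500 nM and 25000 nM.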

Compound 4, half-maximal inhibitory concentration: 8700 nM
Compound 4: the middle estimate sits 1.1-fold (0.04 log units) above what was measured; measured number inside the range.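

In this assay, for the compounds shown here, fluoro para to a large group gives a 1.3-fold higher number from compound 1 to compound 4 (0.11 log units; within the scatter), so this is the first change on the phenyl of compound 1 whose step stays within the scatter, and the position accepts this single atom without a readable loss. The 4-fluorophenyl ring also separates from the two methoxy-bearing rings, with an at least 2.8-fold lower number from compound 3 to compound 4 (0.45 log units; beyond the scatter) and an at least 2.8-fold lower number from compound 2 to compound 4 (0.45 log units; beyond the scatter), and both sizes are only bounds. Compound 2 and compound 3 each return a limit rather than a number, which also leaves the step between those two unreadable: the limit of > 25000 nM in this assay, at which 2 of the 4 values shown sit.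

Going by these compounds, whether this tolerance holds for groups other than fluoro at the same place remains open, for instance chloro, trifluoromethyl, a single methoxy, an amine or a carboxylic acid, and so does the effect of fluoro elsewhere on the ring. No step shown leads to a lower number than compound 1 gives, 6800 nM, so it also remains open whether any change on this phenyl can strengthen the activity.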